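Trifluoromethyl added to compound 3: a step near the limit

A few compounds are considered here, and "the series" means these few. Any claim that something is new, unique, unknown or untested is made for them only; others in the source may bear on it.

Measured in an ADME assay on BHK-21 cells (Mesocricetus auratus) for cytotoxicity, read by MTT assay; a higher number here means that more compound is tolerated, a lower number that less compound is tolerated:
Compound 1 `CC(=O)c1ccc2[nH]c(-c3ccccc3)nc2c1`: > 100000 nM
Compound 2 `COc1ccc(-c2nc3cc(C(C)O)ccc3[nH]2)cc1`: > 100000 nM
Compound 3 `CC(=O)c1ccc2c(c1)nc(-c1ccccc1)n2C1CCCCC1`: 100000 nM

Compound 1 gives > 100000 nM, which is a limit. Compound 2 gives > 100000 nM, also a limit. Among the compounds with values here, compound 3, at 100000 nM, therefore holds the only actual number here.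

Compound 4 `CC(=O)c1ccc2c(c1)nc(-c1ccc(C(F)(F)F)cc1)n2C1CCCCC1` carries trifluoromethyl in place of hydrogen on an aromatic carbon, para to a large group: trifluoromethyl in place of hydrogen on an aromatic carbon.

Within the data shown here, the sole measured step, a number no higher from compound 1 to compound 3 (the limit leaves the size open), involves a different change, and its size stays open due to the limit of > 100000 nM in this assay, at which 2 of the 3 values shown sit. It offers no guide to size, so no step beyond the scatter is expected in this assay. The estimated step is a 1.3-fold lower number from compound 3 to compound 4 (0.10 log units; within the scatter). Compound 4 is expected at 80000 nM, with an estimated range of 30000 nM to 200000 nM.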

Compound 4, half-maximal cytotoxic concentration: 33000 nM
For compound 4 the middle estimate is 2.4-fold (0.38 log units) above the measured one, within the range that was stated.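

In this assay, trifluoromethyl in place of hydrogen on an aromatic carbon, para to a large group, gives a 3.0-fold lower number from compound 3 to compound 4 (0.48 log units; beyond the scatter), so less compound is tolerated. Within the data shown here, this is the first step here whose size can be read, and it lies beyond the scatter. The earlier step gave no such size due to a limit: the limit of > 100000 nM in this assay, at which 2 of the 4 values shown sit.

One change at one place cannot show whether this drop is particular to trifluoromethyl. A chlorine atom, a nitrile or an amine at the same carbon could tell, and so could trifluoromethyl on the core of compound 1.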